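The compounds below may be only part of what the source reports. "The series", "measured", "known", "first", "only" and "open" are said of these compounds alone.

Compound 1 `CN(C)C(=O)c1cc2cnc(Nc3ccc(NC(=O)C4(C(=O)Nc5cccc(F)c5)CC4)cc3)nc2n1C1CCCC1` gives 87% in growth inhibition
Compound 2 `CN(C)C(=O)c1cc2cnc(Nc3ccc(NC(=O)C4(C(=O)Nc5cccc(Cl)c5)CC4)cc3)nc2n1C1CCCC1` gives 84.1% in growth inhibition

In a functional assay on NCI-H1299 cells (Homo sapiens) for inhibition, read by CCK-8 assay, with a stated time of 72 h, tested at 10 uM (a higher number here means more inhibition of growth at the concentration tested, a lower number less inhibition of growth), compound 2 gives 84.1% and stands level with compound 1 within the usual scatter of such measurements. The move from compound 2 to compound 3 `CN(C)C(=O)c1cc2cnc(Nc3ccc(NC(=O)C4(C(=O)Nc5cccc(Br)c5)CC4)cc3)nc2n1C1CCCC1` is one small swap, bromo in place of chloro on an aromatic carbon (in words, bromo in place of chloro on an aromatic carbon, meta to a large group). Within the data shown here, only one measured step is of a similar kind, a swap of one halogen for another. That step is a number 2.9 percentage points lower from compound 1 to compound 2 (within the scatter) and it comes from chloro in place of fluoro on an aromatic carbon. A single step of that size gives no direction, so no change beyond the scatter is expected in this assay here. The expected step is a number 0.1 percentage points lower from compound 2 to compound 3 (within the scatter) and it amounts to no real change. Compound 3 is estimated at 84% with an expected range from 74% to 92% for a repeated measurement.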

Compound 3, percent growth inhibition at one concentration: 77.5%
For compound 3 the middle estimate is 6.5 percentage points above the measured one; measured number inside the range.
By their numbers in this assay, from the lowest: compounds 3, 2 and 1 (each within the scatter of the next).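

With bromo in place of chloro, this assay shows a number 6.6 percentage points lower from compound 2 to compound 3 (within the scatter) and with bromo in place of fluoro it shows a number 9.5 percentage points lower from compound 1 to compound 3 (within the scatter) on the same aromatic carbon. Three halogens have now been read at this one place, meta to a large group, and since all three compounds stand level within the scatter, the place accepts any of them without a change that can be told apart from repeat measurement. Nothing shown here bears on what lies behind these numbers.

From the compounds shown here alone, whether this tolerance extends beyond halogens remains open: a methoxy group, a nitrile or an amine at this place could behave quite differently. Also open, going by these compounds, is whether the three compounds would stay level at other concentrations, as a single concentration cannot show this.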